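From hydroxy to methoxy on compound 3

The source may hold more compounds than are shown below. What is called first, only, known or untested is meant among the compounds shown, and "the series" means these compounds.

Compound 1 `COc1cc(O)cc(/C=C/c2ccc(OC)c(O)c2OC)c1`: > 100000 nM
Compound 2 `COc1cc(O)cc(/C=C/c2cccc(OC)c2OC)c1`: > 100000 nM
Compound 3 `COc1cc(O)cc(/C=C/c2cccc(O)c2O)c1`: > 100000 nM

These three results all come from an ADME assay on QSG7701 cells (Homo sapiens) for cytotoxicity, read by MTT assay, with a stated time of 24 h; on this read-out higher numbers stand for weaker inhibition and lower numbers for stronger inhibition. In this assay compound 3 gives > 100000 nM, which is a limit of the assay and not a number. The entries for compound 1 and compound 2 are limits of the same kind. Among the measured compounds shown here, the whole record so far is the limit of > 100000 nM in this assay, at which 3 of the 3 values shown sit, so none of the three compounds has yet given an actual number, and no measured step is available as a guide.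

The next compound is compound 4 `COc1cc(O)cc(/C=C/c2cccc(O)c2OC)c1`. It differs from compound 3 at a single place: methyl in place of hydrogen on an oxygen on an aromatic ring. In words, there is methyl in place of hydrogen on an oxygen on an aromatic ring, a change that reads as hydroxy to methoxy.

With only the limit of > 100000 nM in this assay, at which 3 of the 3 values shown sit, to go on, no step beyond the scatter is expected in this assay, in either direction, and compound 4 is expected to be reported at the same limit. The expected change is a number no higher from compound 3 to compound 4 (the limit leaves the size open), which is an estimate and not a result. For compound 4 the estimated value is 100000 nM, with an expected range from 50000 nM to 200000 nM.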

Compound 4, half-maximal inhibitory concentration: > 100000 nM
Compound 4: a limit, no number; the forecaster's own chance of this, stated with the estimate: 85%; the middle value lies on the limit itself.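

In this assay compound 4 gives > 100000 nM, which is a limit of the assay and not a number. Its steps to compound 1, compound 2 and compound 3 cannot be read, because all four compounds sit at the same limit: the limit of > 100000 nM in this assay, at which 4 of the 4 values shown sit.

The compounds shown leave open what actual number any of them would give, and whether hydroxy to methoxy changes that number at all.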